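A Larger Ring Group on the Chain of Compound 1

The compounds below may be only part of what the source reports. "The series", "measured", "known", "first", "only" and "open" are said of these compounds alone.

Measured compounds:
compound 1 `O=C(NCCCO)C(c1ccccc1)c1ccccc1` 1000000 nM
compound 2 `O=C(NCCCO)C(c1ccccc1)(c1ccccc1)c1ccccc1` 1000000 nM

In an assay for inhibition of Deoxyuridine 5'-triphosphate nucleotidohydrolase, mitochondrial (Homo sapiens), read by spectrophotometry (a lower number here means a stronger inhibitor, a higher number a weaker inhibitor), compound 1 gives 1000000 nM, and it stands level with compound 2 at the digits shown. Within the data shown here, the one measured step, no change at the digits printed from compound 1 to compound 2 (within the scatter), lies within the scatter. Compound 3 `O=C(NCCCn1ccc(=O)[nH]c1=O)C(c1ccccc1)c1ccccc1` differs from compound 1 in this way: a group of 8 heavy atoms (4 carbon, 2 nitrogen, 2 oxygen; one six-membered aromatic ring with 2 hetero atoms) in place of one oxygen atom, on a saturated chain carbon, three bonds along the chain from an amide-type nitrogen. Among the measured compounds shown here, the step from compound 1 to compound 2 changes a different position and therefore does not bear on this change; no measured step covers the entering group. For the measured compounds named here, what is known is only that compound 1 and compound 2 sit at the same weak value in this assay. With nothing to anchor the change, compound 3 is estimated at 30000 nM, with a range from 3000 nM to 1000000 nM. This estimate means a step of a 33-fold lower number from compound 1 to compound 3 (1.52 log units; beyond the scatter), expected to be toward a stronger inhibitor but held with little confidence.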

Compound 3, inhibition constant: 286000 nM
Beside the measured number, compound 3's estimate is 9.5-fold (0.98 log units) below it; measured number inside the range.
By their numbers in this assay, from the lowest: compound 3; then compounds 1 and 2 (each within the scatter of the next).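

Putting the group with the six-membered aromatic ring in place of the hydroxy oxygen, on a saturated chain carbon three bonds along the chain from an amide-type nitrogen, gives in this assay a 3.5-fold lower number from compound 1 to compound 3 (0.54 log units; beyond the scatter). This position therefore responds to a change, which the earlier step at a different position, no change at the digits printed from compound 1 to compound 2 (within the scatter), could not show, though the shift toward a stronger inhibitor is only modest. Nothing among the data given accounts for this shift.

On these data alone, it remains open whether the whole entering group is needed or only part of it, and how a plain amine or a carboxylic acid would read in the same place. Also open, as far as these compounds go, is whether a longer chain carrying the same ring group would lower the number further, and whether phenyl in place of hydrogen would matter on compound 3.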